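Methyl moved on the benzyl ring of a hydroxamic acid

This account rests on a few compounds, and the source may have more. Where it says the series, first, only, none or still open, it means among the compounds named here.

A small series of hydroxamic acids sharing one core was tested in a functional assay on PC-3 cells (Homo sapiens) for inhibition, read by sulforhodamine B assay; on this read-out higher numbers stand for weaker inhibition of growth and lower numbers for stronger inhibition of growth. Compound 1, `O=C(CCC1=CCCN(Cc2ccc(F)cc2)C1=O)NO`, carries a fluorine on its benzyl ring, but in this assay compound 1 gives "not determined" (no result reported), that is, no result was reported for it. Among the measured compounds shown here, compound 2, `Cc1ccc(CN2CCC=C(CCC(=O)NO)C2=O)cc1`, is the only member with a number: in this assay compound 2 gives 8100 nM, so it stands alone among the values shown and cannot be ranked against anything else.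

Compound 3, `Cc1ccccc1CN1CCC=C(CCC(=O)NO)C1=O`, is built from the same atoms as compound 2, joined differently: 2-methylphenyl in place of 4-methylphenyl on a saturated chain carbon bound to an amide-type nitrogen in a ring. For the measured compounds named here, no step between two measured compounds is available to guide a prediction for such a change. The author therefore expects the step of a 1.1-fold higher number from compound 2 to compound 3 (0.05 log units; within the scatter) to stay within the scatter of repeated measurements, in no clear direction. For compound 3 in this assay the estimate is 9000 nM, with a plausible range from 3500 nM to 25000 nM.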

Compound 3, concentration for 50% growth inhibition: > 10000 nM
Compound 3: no number, only a limit; the forecaster's own chance of this, stated with the estimate: 10%; middle value at least 1.1-fold (0.04 log units) from the limit.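

Compound 3 gives > 10000 nM in this assay, which is a limit of the assay and not a number. Placing the methyl differently on the benzyl ring gives an at least 1.2-fold higher number from compound 2 to compound 3 (0.09 log units; that floor lies within the scatter), so this change offers a floor rather than a measured size, and that floor alone does not set the two compounds apart. This is the first comparison at this position, and its one new reading ends at a limit: the limit of > 10000 nM in this assay, at which 1 of the 3 values shown sits.

On these data alone, how far compound 3 truly lies from compound 2 stays open, and compound 1 has no result, so its fluorine cannot be compared with either methyl. Also open, as far as these compounds go, is how a methoxy group or a chlorine on the same ring, or a longer chain leading to the hydroxamic acid, would read.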